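This account rests on a few compounds, and the source may have more. Where it says the series, first, only, none or still open, it means among the compounds named here.

Compound 1 `COc1ccc2c(/C=C/C(=O)c3cc(N)c(OC)c(OC)c3)cn(C)c2c1`: 156 nM
Compound 2 `COc1ccc2c(/C=C/C(=O)c3cc(OC)c(OC)c(SC)c3)cn(C)c2c1`: 145 nM

Among the compounds with values here, in a functional assay on A2780 cells (Homo sapiens) for antiproliferative activity, read by MTT assay, with a stated time of 48 h (a higher number here means a weaker inhibitor, a lower number a stronger inhibitor), compound 2 at 145 nM stands level, within the scatter, with compound 1, the only other measured compound. Compound 3 `COc1ccc2c(/C=C/C(=O)c3cc(OC)c(OC)c([N+](=O)[O-])c3)cn(C)c2c1` has nitro in place of methylsulfanyl on an aromatic carbon. Within the data shown here, one measured step bears on this carbon: putting methylsulfanyl in place of amino gave a 1.1-fold lower number from compound 1 to compound 2 (0.03 log units; within the scatter), within the scatter. Nitro itself has not been tested, so this is thin evidence, and the range stays wide. The expected change is a 1.4-fold higher number from compound 2 to compound 3 (0.14 log units; within the scatter), with no shift beyond the scatter anticipated. For compound 3 the estimated value is 200 nM, with an expected range of 60 nM to 700 nM.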

Compound 3, half-maximal inhibitory concentration: 952 nM
For compound 3 the middle estimate is 4.8-fold (0.68 log units) below the measured one, outside the stated range (above it).
By their numbers in this assay, from the lowest: compounds 2 and 1 (each within the scatter of the next); then compound 3.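

In this assay this aromatic carbon proves not to be indifferent to its group: amino and methylsulfanyl stand level, whereas nitro brings a 6.6-fold higher number from compound 2 to compound 3 (0.82 log units; beyond the scatter) and a 6.1-fold higher number from compound 1 to compound 3 (0.79 log units; beyond the scatter), so a change here can cost activity. The earlier pair could not show this, since its step stayed within the scatter. No measurement shown explains why nitro parts from the other two groups.

From the compounds shown here alone, whether chlorine, a nitrile or a carboxylic acid on this carbon would stand with nitro or with the other two remains open. So does whether nitro would have the same effect on another carbon of the shared core.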